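A Chlorine Swap on the Benzyl Arm

This account rests on a few compounds, and the source may have more. Where it says the series, first, only, none or still open, it means among the compounds named here.

Three compounds have so far been measured in an assay on isolated protein for inhibition of protein deacetylase HDAC6 (Homo sapiens), with a stated time of 60 min; on this read-out higher numbers stand for weaker inhibition and lower numbers for stronger inhibition:

Compound 1 `O=C(CCCCCn1cc(Nc2ncc3ccn(Cc4ccccc4F)c3n2)cn1)NO`: 15.3 nM
Compound 2 `O=C(CCCCCCn1cc(Nc2ncc3ccn(Cc4ccccc4F)c3n2)cn1)NO`: 8.4 nM
Compound 3 `O=C(CCCCCn1cc(Nc2ncc3ccn(Cc4cccc(F)c4)c3n2)cn1)NO`: 13.7 nM

All three share the same core and differ only in the length of the chain carrying the hydroxycarbamoyl group or in where the fluorine sits on the benzyl ring. Compound 2 gives the lowest number of the three, but its margin over the others is small: a 1.8-fold lower number from compound 1 to compound 2 (0.26 log units; within the scatter), and the gap to compound 3 is likewise within the scatter, so no ordering among them can be claimed.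

Compound 4 `O=C(CCCCCCn1cc(Nc2ncc3ccn(Cc4cccc(Cl)c4)c3n2)cn1)NO` is not yet measured. It differs from compound 2 in one place: 3-chlorophenyl in place of 2-fluorophenyl on a saturated chain carbon bound to an aromatic nitrogen. The closest measured step is the move of the fluorine around the ring, a 1.1-fold lower number from compound 1 to compound 3 (0.05 log units; within the scatter), which left the number essentially unchanged. For the measured compounds named here, no measured pair tells how chlorine compares with fluorine here, so the expectation rests only on that one step and on the general steadiness of this series. Compound 4 is therefore expected to sit close to compound 2, with a 1.0-fold higher number from compound 2 to compound 4 (0.01 log units; within the scatter), giving an estimate of 8.5 nM within a range of 3 nM to 25 nM.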

Compound 4, half-maximal inhibitory concentration: 36.8 nM
Compound 4: the middle estimate sits 4.3-fold (0.64 log units) below what was measured, outside the stated range (above it).
By their numbers in this assay, from the lowest: compounds 2, 3 and 1 (each within the scatter of the next); then compound 4.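

In this assay, replacing 2-fluorobenzyl with 3-chlorobenzyl on the saturated chain carbon bound to an aromatic nitrogen gives the first step among these compounds to lie beyond the scatter (a 4.4-fold higher number from compound 2 to compound 4 (0.64 log units; beyond the scatter)), so the benzyl arm can affect the read-out, though modestly. The earlier change on this arm only moved the fluorine, on the chain of compound 1, and stayed within the scatter (a 1.1-fold lower number from compound 1 to compound 3 (0.05 log units; within the scatter)), whereas the new step changes both the halogen and its place on the ring, on the chain of compound 2. Nothing available explains why the number rises in this step.

The compounds shown cannot say whether the rise follows the chlorine, its place on the ring, or the two together, and a 2-chlorobenzyl or 3-fluorobenzyl arm on the chain of compound 2 would help separate these possibilities. From the compounds shown here alone, it also remains open how this position would respond to other groups, such as a plain benzyl, a 3-bromobenzyl or a 3-methylbenzyl.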